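The source may report more compounds than this note shows. Statements on the series, on what has been measured and on what is new or still open speak of the compounds shown alone.

Compound 3 `COc1ccc(C(=O)Nc2cccc(NC(=O)COc3ccc4c(=O)ccoc4c3)c2)cc1` is the strongest of the three compounds examined in an assay on isolated protein for inhibition of Rho-associated protein kinase 2 (Homo sapiens), read by scintillation counting, radiometric assay and 33P incorporation, with a stated time of 40 min, in the presence of a further agent that is not named here (a higher number here means a weaker inhibitor, a lower number a stronger inhibitor), where compound 3 gives 7 nM. In this assay compound 2 `Cc1c(OCC(=O)Nc2cccc(NC(=O)c3ccc(N(C)C)cc3)c2)ccc2c(=O)ccoc12` gives 4160 nM, and compound 1 `CN(C)c1ccc(C(=O)Nc2cccc(NC(=O)COc3ccc4c(c3)CCC(=O)N4)c2)cc1` gives 9970 nM; both of these numbers lie far above that of compound 3, well beyond the usual scatter, though each of these two compounds differs from compound 3 in more than one place, so no single change can be named for those gaps.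

Compound 4 `NCc1ccc(C(=O)Nc2cccc(NC(=O)COc3ccc4c(=O)ccoc4c3)c2)cc1` differs from compound 3 in one place: aminomethyl in place of methoxy on an aromatic carbon. Among the measured compounds shown here, no measured pair shows the effect of this exact change, so the expectation here rests only on compound 3. A modest step is expected, a 2.1-fold higher number from compound 3 to compound 4 (0.33 log units; beyond the scatter), in either direction, possibly none beyond the scatter. Compound 4 is therefore estimated at 15 nM, within a range of 3 nM to 80 nM.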

Compound 4, half-maximal inhibitory concentration: 66 nM
Estimate against measurement, compound 4: 4.4-fold (0.64 log units) below, within the range that was stated.
By their numbers in this assay, from the lowest: compound 3; then compound 4; then compound 2; then compound 1.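

In this assay, among the compounds shown here, aminomethyl in place of methoxy gives a 9.4-fold higher number from compound 3 to compound 4 (0.97 log units; beyond the scatter), the first single change that can be read. This position therefore accepts a group with one more hydrogen-bond donor, at a modest cost in inhibition. Nothing available here explains this step.

The compounds shown leave open whether the amine itself or the carbon carrying it accounts for the step, since neither a hydroxymethyl group nor an amino group attached directly to the ring appears among them. Going by these compounds, how a carboxylic acid or a longer chain ending in an amine would compare also remains open.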